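This account rests on a few compounds, and the source may have more. Where it says the series, first, only, none or still open, it means among the compounds named here.

Among the measured compounds shown here, in a physicochemical assay for lipophilicity, in phosphate buffer, measured as octanol-water partition, at pH 11.5 (on this read-out higher numbers stand for higher lipophilicity and lower numbers for lower lipophilicity), compound 3 `CCCCCCCCCCCCNC(=N)NC(=N)Nc1ccc(Cl)cc1` reads 7.13, the highest of the three numbers so far. Compound 2 `CCCCC(CC)CNC(=N)NC(=N)Nc1ccc(Cl)cc1`, at 4.93, is the nearest to it and compound 1 `CCCCCCCCNC(=N)NC(=N)Nc1ccccc1`, at 4.43, the furthest, and both lie lower by more than the scatter.

Compound 4 `CCCCCCCCNC(=N)NC(=N)Nc1ccc(Cl)cc1` differs from compound 3 by hydrogen in place of butyl on a saturated chain carbon, eight bonds along the chain from an amine nitrogen. For the measured compounds named here, no measured pair differs in one place only, so the size of this step has to be judged indirectly.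

Compound 2 keeps the chlorine of compound 3 but has a shorter, branched chain, and compound 2 reads 4.93. Compound 1 has the chain of compound 4 without the chlorine, and compound 1 reads 4.43. On these two values, compound 4 is expected to fall well under compound 3, near compound 2 and somewhat over compound 1. The expected change in this assay is a number 2.03 log units lower from compound 3 to compound 4 (beyond the scatter), a fall beyond the scatter. The estimate for compound 4 is 5.1, with an expected range of 4.7 to 5.5.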

Compound 4, partition coefficient: 5.13
Compound 4: middle estimate off by 0.03 log units, on the low side; the range from low to high includes it.
By their numbers in this assay, from the lowest: compound 1; then compounds 2 and 4 (each within the scatter of the next); then compound 3.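

In this assay the series now has its first steps that change one place only. Hydrogen in place of butyl on a saturated chain carbon, eight bonds along the chain from an amine nitrogen, gives a number 2.00 log units lower from compound 3 to compound 4 (beyond the scatter), a large step, while chloro in place of hydrogen on an aromatic carbon gives a number 0.70 log units higher from compound 1 to compound 4 (beyond the scatter), a modest one, so in this assay the chain change outweighs the aromatic change in these two pairs. Heptyl in place of 1-ethylpentyl on a saturated chain carbon bound to an amine nitrogen gives a number 0.20 log units higher from compound 2 to compound 4 (within the scatter), which lies within the scatter, so this assay does not separate these two chains, and no measurement at hand explains any of the three steps.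

Open, from the compounds shown here alone, are the chain lengths between those of compound 4 and compound 3, and whether a longer chain would continue the same trend. Also open, going by these compounds, are whether the chloro step keeps its size on the chain of compound 3, and what a fluoro or methoxy group would give on that aromatic carbon.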